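A few compounds are considered here, and "the series" means these few. Any claim that something is new, unique, unknown or untested is made for them only; others in the source may bear on it.

Measured compounds in hand:
- compound 1, `Cc1cc(NNC(=O)Nc2cc(Cl)nc(Cl)c2)ncc1-c1cnn(C)c1`: 2600 nM
- compound 2, `Cc1cc(NNC(=O)Nc2cc(Cl)nc(Cl)c2)ncc1-c1cn(C)nc1C`: > 1400 nM
- compound 3, `Cc1cc(CNC(=O)Nc2cc(OCCO)nc(C(F)(F)F)c2)nnc1-c1cn(C)nc1C(F)(F)F`: 348000 nM

All three were run in a functional assay on CHO cells for antagonist activity at sphingosine 1-phosphate receptor 2 (Homo sapiens), read by fluorescence and calcium flux, with a stated time of 3 min; on this read-out lower numbers stand for stronger inhibition and higher numbers for weaker inhibition. Compound 1 gives 2600 nM. For compound 2 the result in this assay is a limit of the assay, > 1400 nM, and (the limit of > 1400 nM in this assay, at which 1 of the 3 values shown sits). The change from compound 1 to compound 2 is methyl in place of hydrogen on an aromatic carbon. The step it made is a step that the limit leaves unreadable from compound 1 to compound 2. Compound 3 gives 348000 nM in this assay, the highest of the two numbers. The difference between the core of compound 3 and the core of compound 1 is not broken down here.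

Compound 4, `Cc1cc(CNC(=O)Nc2cc(C(F)(F)F)nc(OCCO)c2C)nnc1-c1cn(C)nc1C(F)(F)F`, has not yet been measured. Its change from compound 3 is methyl in place of hydrogen on an aromatic carbon. This is the same kind of change as from compound 1 to compound 2, but the surroundings differ: in compound 2 the methyl enters on a five-membered aromatic ring with 2 nitrogen, next to the ring nitrogen and next to the ring atom that bears a large group; in compound 4 it enters on a six-membered aromatic ring with 1 nitrogen, ortho to a 2-hydroxyethoxy group and para to a trifluoromethyl group. Within the data shown here, the one measured instance of this change cannot be read. The step from compound 3 to compound 4 is expected to be small, a 1.2-fold lower number from compound 3 to compound 4 (0.06 log units; within the scatter), resting on compound 3 at 348000 nM as the only anchor. Compound 4 is expected to give about 300000 nM in this assay, within 100000 nM to 1000000 nM.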

Compound 4, half-maximal inhibitory concentration: 84000 nM
Compound 4: the middle estimate sits 3.6-fold (0.55 log units) above what was measured, and the stated range ends above it.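

In this assay, methyl in place of hydrogen on an aromatic carbon of the six-membered aromatic ring with 1 nitrogen, ortho to a 2-hydroxyethoxy group and para to a trifluoromethyl group, gives a 4.1-fold lower number from compound 3 to compound 4 (0.62 log units; beyond the scatter). The other instance of this change, on the five-membered aromatic ring with 2 nitrogen, cannot be read because compound 2 carries a limit of the assay and not a number: the limit of > 1400 nM in this assay, at which 1 of the 4 values shown sits. The series therefore offers one readable step on one core, which shows what the change does at this place in compound 4 but does not show whether it carries over to the core of compound 1 or to any other place.

The compounds shown leave open whether the lower number is particular to methyl at this ring carbon, or whether an ethyl group or an amine there would give a step of similar size. They also leave open whether the step would hold if the 2-hydroxyethoxy group were exchanged for a longer chain or a carboxylic acid.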